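Lengthening the alkoxy chain of compound 2

The source may report more compounds than this note shows. Statements on the series, on what has been measured and on what is new or still open speak of the compounds shown alone.

Of the compounds shown here, three that share one core have been measured in a functional assay on the whole organism (strain Wistar) for inhibition, with Rattus norvegicus as the target, read by paw edema, with stated times of 30 min and 3 h, at a dose of 100 mg/kg by the oral route; on this read-out lower numbers stand for less inhibition and higher numbers for more inhibition at the one dose given (going by the name of the read-out). Compound 1 `COc1cc(C(N)=O)nn1-c1ccccc1` gives 34.3% in this assay. Compound 2 `COc1cc(C(=O)N(C)C)nn1-c1ccccc1` gives 47.5% in this assay, and compound 3 `CCCCNC(=O)c1cc(OC)n(-c2ccccc2)n1` gives 20.6% in this assay. Compound 2 therefore stands highest of the three numbers, with compound 1 nearest and compound 3 furthest: the step of a number 13.2 percentage points higher from compound 1 to compound 2 (beyond the scatter) and the step of a number 26.9 percentage points lower from compound 2 to compound 3 (beyond the scatter) both lie beyond the scatter, as does the step of a number 13.7 percentage points lower from compound 1 to compound 3 (beyond the scatter).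

Compound 4 `CCOc1cc(C(=O)N(C)C)nn1-c1ccccc1` differs from compound 2 by methyl in place of hydrogen on a saturated chain carbon bound to an oxygen on an aromatic ring. None of the three measured steps touches this place: each of them alters the substituents on the carbonyl carbon of the amide, and each was modest in size. Within the data shown here, the data thus hold no step that bears directly on the change from compound 2 to compound 4, and nothing in them suggests a movement in either direction. The step of a number 1.5 percentage points lower from compound 2 to compound 4 (within the scatter) is therefore expected to stay within the scatter of this assay. Compound 4 is estimated to give 46%, with a range from 30% to 60%, in this assay.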

Compound 4, a percentage reported as inhibition, in the whole organism at one dose (the size of the read-out at that dose, not a potency): 65.8%
Estimate against measurement, compound 4: 19.8 percentage points below, and the stated range ends below it.
By their numbers in this assay, from the lowest: compound 3; then compound 1; then compound 2; then compound 4.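

Among these compounds, the alkoxy group on the shared core, which none of the earlier steps touched, proves to be a place where this read-out can move: in this assay, going from methoxy to ethoxy gives a number 18.3 percentage points higher from compound 2 to compound 4 (beyond the scatter). The earlier compounds shown here showed changes only on the carbonyl carbon, whereas this result shows that a methyl on a saturated chain carbon bound to an oxygen on an aromatic ring, adding a single carbon and no hydrogen-bond donor or acceptor, is enough to shift the number while the dimethylamino amide stays in place. Nothing in the information at hand accounts for this rise.

The compounds shown leave open whether the number would keep rising with a longer chain such as propoxy or butoxy, or how it would respond to a branched isopropoxy group. They also leave open whether ethoxy would bring a similar rise with the amino group of compound 1 or the butylamino group of compound 3, and whether the step seen at this one dose would hold at other doses.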